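This account rests on a few compounds, and the source may have more. Where it says the series, first, only, none or still open, it means among the compounds named here.

Working notes on the series in a functional assay on the whole organism (strain Jcl:SD) for inhibition, with Rattus norvegicus as the target, with stated times of 3 min and 3 h, at a dose of 1 mg/kg by the intravenous route; on this read-out higher numbers stand for more inhibition at the one dose given (going by the name of the read-out) and lower numbers for less inhibition.

Compound 1 `CNCc1cc(-c2ccccc2)n(S(=O)(=O)c2ccc(C)cc2)c1` gives 66% in this assay. Compound 2 `CNCc1cc(-c2ccccc2C)n(S(=O)(=O)c2ccc(C)cc2)c1` gives 92%, and compound 3 `CNCc1cc(-c2ccccc2F)n(S(=O)(=O)c2ccc(C)cc2)c1` gives 91%. The step of a number 26 percentage points higher from compound 1 to compound 2 (beyond the scatter) and the step of a number 25 percentage points higher from compound 1 to compound 3 (beyond the scatter) are both beyond the scatter and of similar size; the step of a number 1 percentage points lower from compound 2 to compound 3 (within the scatter) is within the scatter, so compound 2 and compound 3 are not separated on these numbers.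

Compound 3 stands second highest of the three; its nearest neighbour is compound 2, within the scatter, and its furthest is compound 1, which lies beyond the scatter below it.

Compound 4 `CNCc1cc(-c2cccc(F)c2)n(S(=O)(=O)c2ccc(C)cc2)c1` differs from compound 3 in that (3-fluorophenyl in place of 2-fluorophenyl on an aromatic carbon). For the measured compounds named here, no measured step moves the fluorine within the ring; the steps that bear on it are those from compound 1, which show only that a substituent on the phenyl ring at the place it occupies in compound 2 and compound 3 raises the number. Going by these compounds, whether a 3-fluorophenyl holds that gain is untested, so part of the gain relative to compound 1 may be lost.

The expected step of a number 11 percentage points lower from compound 3 to compound 4 (beyond the scatter) is therefore a modest fall, and compound 4 is estimated at 80%, with a range from 60% to 95%.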

Compound 4, a percentage reported as inhibition, in the whole organism at one dose (the size of the read-out at that dose, not a potency) in the Rattus norvegicus assay: 77%
The estimate for compound 4 lay 3 percentage points above the measured number, and the stated range covers the measured number.
By their numbers in the Rattus norvegicus assay, from the lowest: compound 1; then compound 4; then compounds 3 and 2 (each within the scatter of the next).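

In the Rattus norvegicus assay the place of the fluorine on the phenyl ring counts: the step of a number 14 percentage points lower from compound 3 to compound 4 (beyond the scatter) shows that 3-fluorophenyl does not hold the level of 2-fluorophenyl, and the step of a number 15 percentage points lower from compound 2 to compound 4 (beyond the scatter) puts it under 2-methylphenyl as well. In the Rattus norvegicus assay the gain over plain phenyl is reduced but not lost, as the step of a number 11 percentage points higher from compound 1 to compound 4 (beyond the scatter) shows, so a fluorine at either place gives a higher number than hydrogen, by a margin that depends on the place. The same change also moves a second read-out: in a physicochemical assay for lipophilicity, read by HPLC, at pH 7.4 (a higher number here means a more lipophilic compound, a lower number a more polar compound), compound 3 gives 1.56 and compound 4 gives 1.98, the step of a number 0.42 log units higher from compound 3 to compound 4 (beyond the scatter) running opposite in direction to the fall in inhibition.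

One pair is too little to tie the two read-outs together across the series. Where 4-fluorophenyl would stand, and whether 3-methylphenyl would lose ground against 2-methylphenyl as 3-fluorophenyl does against 2-fluorophenyl, stays open.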